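Moving the Pyridyl Nitrogen on a Dihydropyridine Ester

This account rests on a few compounds, and the source may have more. Where it says the series, first, only, none or still open, it means among the compounds named here.

Compound 1 `CC1=NC(C)=C([N+](=O)[O-])C(c2cccnc2)/C1=C(\O)OC(C)C` was tested in a functional assay (cardiac atrium) for agonist activity, with Cavia porcellus as the target (a higher number here means that more compound is needed for the effect, a lower number that less compound is needed), where compound 1 gives 28500 nM. Within the data shown here, that is the highest of the three numbers so far. Compound 2 `CC1=NC(C)=C([N+](=O)[O-])C(c2cccnc2)/C1=C(\O)OC1CCCC1` gives 3280 nM in this assay, and compound 3 `CC1=NC(C)=C([N+](=O)[O-])C(c2cccnc2)/C1=C(\O)OCC(C)C` gives 1740 nM. The three measured steps all alter the ester group on the shared core: an 8.7-fold lower number from compound 1 to compound 2 (0.94 log units; beyond the scatter), a 16-fold lower number from compound 1 to compound 3 (1.21 log units; beyond the scatter), and a 1.9-fold lower number from compound 2 to compound 3 (0.28 log units; within the scatter).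

Among the measured compounds shown here, compound 4 `CC1=NC(C)=C([N+](=O)[O-])C(c2ccncc2)/C1=C(\O)OC(C)C` differs from compound 1 in another place entirely. pyridin-4-yl in place of pyridin-3-yl on a saturated ring carbon None of the measured steps touches the pyridin-3-yl group, so no measured step bears directly on this change, and the size of the earlier ester steps says nothing about it. For the measured compounds named here, the only guide is the starting point. Because compound 1 gives 28500 nM in this assay, compound 4 is expected to stay near it, and the expected step is a 1.1-fold higher number from compound 1 to compound 4 (0.02 log units; within the scatter), that is, none beyond the scatter in either direction. The estimate for compound 4 is 30000 nM, with a wide range from 8000 nM to 120000 nM to reflect the absence of any comparable measured step.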

Compound 4, half-maximal effective concentration: 8050 nM
For compound 4 the middle estimate is 3.7-fold (0.57 log units) above the measured one, within the range that was stated.
By their numbers in this assay, from the lowest: compounds 3 and 2 (each within the scatter of the next); then compound 4; then compound 1.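

In this assay, the group on the saturated ring carbon matters as well as the ester: with the isopropyl ester held fixed, the measurements show a 3.5-fold lower number from compound 1 to compound 4 (0.55 log units; beyond the scatter). This is a modest step, but it lies beyond the scatter, so this position is not silent, as the earlier ester steps alone could not reveal. Pyridin-3-yl and pyridin-4-yl have the same heavy atoms, the same kind of six-membered aromatic ring and the same counts of hydrogen-bond donors and acceptors, so the step comes from a change in how those atoms are joined, and nothing measured here gives a reason for its direction or size.

On these data alone, the pyridin-4-yl group appears here only with the isopropyl ester, so it remains open whether the same step would appear with the cyclopentyl ester of compound 2 or the isobutyl ester of compound 3. Also open, as far as these compounds go, is how a pyridin-2-yl group or a plain phenyl ring on the same saturated ring carbon would read in this assay.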